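The source may report more compounds than this note shows. Statements on the series, on what has been measured and on what is new or still open speak of the compounds shown alone.

Measured so far:
compound 1 `CC(C)COC(=O)Nc1ccc([Se][Se]c2ccc(NC(=O)OCC(C)C)cc2)cc1` — 13100 nM
compound 2 `CCCCOC(=O)Nc1ccc([Se]C#N)cc1` — 5000 nM

In an ADME assay on BEAS-2B cells (Homo sapiens) for cytotoxicity, read by MTT assay, with a stated time of 72 h (on this read-out higher numbers stand for weaker inhibition of growth and lower numbers for stronger inhibition of growth), compound 1 gives 13100 nM and compound 2 gives 5000 nM. Within the data shown here, compound 2 stands at the lowest of the two numbers; the only other number, that of compound 1, sits higher by a gap beyond the usual scatter. Among the measured compounds shown here, the two measured compounds do not differ in a single place, so no step between measured compounds can be read from them.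

Compound 3 `C=CCOC(=O)Nc1ccc([Se]C#N)cc1` has not been measured. Against compound 2 it shows (vinyl in place of propyl on a saturated chain carbon bound to an oxygen next to a carbonyl group). The measured pair says nothing about this change on its own, so no shift beyond the scatter is expected in either direction. The expected step is a 1.1-fold higher number from compound 2 to compound 3 (0.04 log units; within the scatter). For compound 3 the estimate is 5500 nM, with a range from 2500 nM to 12000 nM.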

Compound 3, concentration for 50% growth inhibition: 21400 nM
Compound 3: middle estimate off by 3.9-fold (0.59 log units), on the low side; the measured number lies above the stated range.
By their numbers in this assay, from the lowest: compound 2; then compounds 1 and 3 (each within the scatter of the next).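

In this assay, the chain end on the oxygen next to the carbonyl group is not a silent place: vinyl in place of propyl on a saturated chain carbon bound to an oxygen next to a carbonyl group gives a 4.3-fold higher number from compound 2 to compound 3 (0.63 log units; beyond the scatter). Read one bond further out, as butyl to allyl, the change shortens the chain and brings in a double bond outside aromatic rings at once, so this single step does not separate the two. No measurement at hand bears on the reason for the step.

Still open, going by these compounds, is whether a propoxy chain, saturated like butoxy and as long as allyloxy, would sit with compound 2 or with compound 3. Also open, on these data alone, is how a benzyl group at this place, or the same butyl to allyl change on the core of compound 1, would read.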